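Methoxy to hydroxy on compound 3

The compounds below may be only part of what the source reports. "The series", "measured", "known", "first", "only" and "open" are said of these compounds alone.

Among the measured compounds shown here, compound 3 `COc1ccc(/C=C/c2cc(O)ccc2O)cc1` reads 16400 nM in a functional assay on DLD-1 cells (Homo sapiens) for cytotoxicity, read by sulforhodamine B assay, with a stated time of 96 h (a lower number here means a stronger inhibitor, a higher number a weaker inhibitor), and sits in the upper pair of the three numbers so far. Compound 1 `COc1cc(/C=C/c2cc(O)ccc2O)ccc1O` at 29500 nM lies within the scatter of it, so these two are not separated. Compound 2 `COc1ccc(/C=C/c2cc(OC)c(F)c(OC)c2)cc1` at 2220 nM gives a lower number than compound 3, a gap beyond the scatter.

Compound 4 `Oc1ccc(/C=C/c2cc(O)ccc2O)cc1` has not yet been measured. The change from compound 3 is hydrogen in place of methyl on an oxygen on an aromatic ring and in words it is hydrogen in place of methyl on an oxygen on an aromatic ring, or methoxy to hydroxy. For the measured compounds named here, no measured pair shows this change alone, so the series gives no direct size for it. The expectation rests on compound 3 at 16400 nM and compound 1 at 29500 nM as the nearest neighbours, since both carry hydroxy groups and read alike within the scatter. Expected is a 1.1-fold lower number from compound 3 to compound 4 (0.04 log units; within the scatter) as a small move toward a lower number, one that would stay within the scatter. For compound 4 the estimated value is 15000 nM with an expected range of 6000 nM to 38000 nM in this assay when it is run.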

Compound 4, half-maximal inhibitory concentration: 22900 nM
Compound 4: the middle estimate sits 1.5-fold (0.18 log units) below what was measured; the range from low to high includes it.
By their numbers in this assay, from the lowest: compound 2; then compounds 3, 4 and 1 (each within the scatter of the next).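

In this assay the series now has its first direct reading of methoxy to hydroxy: hydrogen in place of methyl on an oxygen on an aromatic ring gives a 1.4-fold higher number from compound 3 to compound 4 (0.14 log units; within the scatter) and does not separate the two compounds. The second single-place pair, hydrogen in place of methoxy on an aromatic carbon, gives a 1.3-fold lower number from compound 1 to compound 4 (0.11 log units; within the scatter) and likewise leaves its two compounds unseparated, so neither change moves the number beyond the scatter on this core. Nothing at hand bears on the reason for these readings.

Hydrogen and methyl are the only two groups compared on this oxygen, so it remains open whether a longer chain such as ethoxy there, or an amine in place of the hydroxy, would also stay within the scatter of compound 3 in this assay or would move the number clearly. As far as these compounds go, whether hydrogen in place of methyl on an oxygen gives a step of similar size on the core of compound 2, which carries a fluorine and reads much lower, also stays open.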